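Sulfonamide Nitrogen Substituent Exchange on a Shared Core

A few compounds are considered here, and "the series" means these few. Any claim that something is new, unique, unknown or untested is made for them only; others in the source may bear on it.

Measured compounds:
compound 1, `Nc1ccc(S(=O)(=O)Nc2ccnc3cc(C(F)(F)F)ccc23)cc1`, 29600 nM
compound 2, `O=C(Nc1ccccc1)Nc1ccc(S(=O)(=O)Nc2ccnc3cc(C(F)(F)F)ccc23)cc1`, 25400 nM
compound 3, `N=C(N)NS(=O)(=O)c1ccc(N/C(S)=N\c2ccnc3cc(C(F)(F)F)ccc23)cc1`, 24300 nM

In a functional assay on HT-1080 cells (Homo sapiens) for antiproliferative activity, read by sulforhodamine B assay, with a stated time of 48 h (on this read-out higher numbers stand for weaker inhibition and lower numbers for stronger inhibition), compound 3 gives 24300 nM, a number within the scatter of both compound 2 and compound 1. Compound 4, `O=S(=O)(Nc1ccccn1)c1ccc(N/C(S)=N\c2ccnc3cc(C(F)(F)F)ccc23)cc1`, differs from compound 3 by a group of 6 heavy atoms (5 carbon, 1 nitrogen; one six-membered aromatic ring with 1 hetero atom) in place of a group of 3 heavy atoms (1 carbon, 2 nitrogen; no ring), on a sulfonamide nitrogen. Among the compounds with values here, the only measured step, a 1.2-fold lower number from compound 1 to compound 2 (0.07 log units; within the scatter), concerns a different nitrogen and was itself within the scatter, so no measured step bears directly on this change. The account therefore expects no step beyond the scatter in this assay, and the step from compound 3 to compound 4 is estimated at a 1.0-fold lower number from compound 3 to compound 4 (0.01 log units; within the scatter). Compound 4 is expected to give 24000 nM, with a range from 7000 nM to 80000 nM.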

Compound 4, half-maximal inhibitory concentration: 28000 nM
Compound 4: the middle estimate sits 1.2-fold (0.07 log units) below what was measured; low and high end bracket the measured number.
By their numbers in this assay, from the lowest: compounds 3, 2, 4 and 1 (each within the scatter of the next).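

In this assay the exchange on the sulfonamide nitrogen, pyridin-2-yl entering for the open group of compound 3, gives a 1.2-fold higher number from compound 3 to compound 4 (0.06 log units; within the scatter) and so stays within the scatter. Within the data shown here, this is the first step read at this position, and it shows that a six-membered aromatic ring can replace a group without a ring with no measurable consequence on this read-out. No measurement at hand offers a reason for this result.

As far as these compounds go, whether a carboxylic acid, an amine or a longer chain on this sulfonamide nitrogen would produce a step beyond the scatter remains open.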